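Side chain rearrangement in the series

The compounds below may be only part of what the source reports. "The series", "measured", "known", "first", "only" and "open" are said of these compounds alone.

Compound 1 `CC[C@H](C)[C@H](NC(=O)CN(c1ncnc2c1ncn2C1CCCCO1)C1CC1)C(=O)OCc1ccccc1` is the reference point. Among the compounds with values here, in a functional assay on the whole organism (Tail, strain ICR) with Mus musculus as the target, in the tail flick test, with a stated time of 30 min, at a dose of 25 umol/kg by the oral route (on this read-out lower numbers stand for a weaker effect and higher numbers for a stronger effect at the one dose given), compound 1 gives 25.6%, the higher of the two numbers so far, though only by a margin within the scatter. Within the data shown here, compound 2 `NC(=O)C[C@H](NC(=O)CN(c1nc(Cl)nc2[nH]cnc12)C1CC1)C(=O)OCc1ccccc1` in this assay gives 24.4%, and the two values show no difference beyond the scatter; compound 2 differs from compound 1 in more than one place, so no single step between them is counted.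

Compound 3 `CC(C)C[C@H](NC(=O)CN(c1ncnc2c1ncn2C1CCCCO1)C1CC1)C(=O)OCc1ccccc1` is the next to be measured. It differs from compound 1 by a single change: isobutyl in place of sec-butyl on a saturated chain carbon bound to an amide-type nitrogen and a carbonyl carbon. The same atoms are joined differently, with no ring, no donor and no acceptor on either side. Among the measured compounds shown here, no step between measured compounds bears on this change. The expected step from compound 1 to compound 3 is a number 0.6 percentage points lower from compound 1 to compound 3 (within the scatter), small, in no firm direction, and not beyond the scatter. Compound 3 is therefore estimated at 25%, with a range from 10% to 40%.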

Compound 3, a percentage reported as activity, at one dose (the size of the read-out at that dose, not a potency): 26.2%
Beside the measured number, compound 3's estimate is 1.2 percentage points below it; measured number inside the range.
By their numbers in this assay, from the lowest: compounds 2, 1 and 3 (each within the scatter of the next).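

In this assay, within the data shown here, isobutyl in place of sec-butyl on a saturated chain carbon bound to an amide-type nitrogen and a carbonyl carbon gives a number 0.6 percentage points higher from compound 1 to compound 3 (within the scatter), the first reading at this position. With the same four carbons joined differently, the two side chains cannot be told apart at this one dose, and the defined stereocentre of sec-butyl, which isobutyl lacks, brings no difference beyond the scatter here. Nothing on hand accounts for this result.

Going by these compounds, whether a phenyl ring, a primary amine, a carboxylic acid or a longer chain on this carbon would separate from compound 1 stays open. Compound 2 differs from compound 1 and from compound 3 in more than one place, so it cannot be read for this position.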